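The compounds below may be only part of what the source reports. "The series", "measured", "known", "first", "only" and "open" are said of these compounds alone.

Of the compounds shown here, three of a shared core have been measured in an assay on isolated protein for inhibition of protein kinase C zeta type (Homo sapiens), with a stated time of 4 min, tested at 62.5 uM; on this read-out lower numbers stand for less inhibition and higher numbers for more inhibition at the one concentration tested (going by the name of the read-out). Compound 1 `CC(C)(C)C1=NN(c2ccc(C(F)(F)F)cc2)C(c2ccc(O)cc2)C1` gives 94.2% in this assay. Compound 2 `CC(C)c1ccc(N2N=C(C(C)(C)C)CC2c2ccc(O)cc2)cc1` gives 54.9%, and compound 3 `CC(C)(C)C1=NN(c2cccc(Cl)c2)C(c2ccc(O)cc2)C1` gives 96.8%. Compound 3 stands highest of the three numbers, but its value sits within the usual scatter of that of compound 1, so no order between these two can be claimed; its value lies far above that of compound 2, a gap that is beyond the scatter.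

For the measured compounds named here, the one measured step, a number 39.3 percentage points lower from compound 1 to compound 2 (beyond the scatter), shows that the ring attached to the ring nitrogen matters a great deal: swapping one substituent on it removed most of the inhibition.

Compound 4 `CC(C)(C)C1=NN(c2ccccc2F)C(c2ccc(O)cc2)C1` is not yet measured. It differs from compound 3 by 2-fluorophenyl in place of 3-chlorophenyl on an amine nitrogen in a ring. Going by the values given here, no measured step covers this exact change. What the data show is that compound 1 and compound 3, both bearing a halogen-type group on that ring, inhibit strongly, while compound 2 with an isopropyl there does not. Because compound 1 gives 94.2% and compound 3 gives 96.8%, a halogen-bearing ring in this position is expected to keep inhibition high, though a move of the halogen to a new spot adds uncertainty. For compound 4 the expected step is a number 12.8 percentage points lower from compound 3 to compound 4 (beyond the scatter), a modest fall at most. The estimate for compound 4 in this assay is 84%, within a range of 58% to 100%.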

Compound 4, a percentage reported as inhibition, at one concentration (the size of the read-out at that concentration, not a potency): 57.6%
Beside the measured number, compound 4's estimate is 26.4 percentage points above it; the whole stated range lies above it.
By their numbers in this assay, from the lowest: compounds 2 and 4 (each within the scatter of the next); then compounds 1 and 3 (each within the scatter of the next).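

In this assay, replacing 3-chlorophenyl with 2-fluorophenyl on the amine nitrogen in the ring gives a number 39.2 percentage points lower from compound 3 to compound 4 (beyond the scatter), so a halogen on this aromatic ring does not by itself keep inhibition high. The two groups match in heavy-atom count, with one six-membered aromatic ring of carbon, no hydrogen-bond donors or acceptors and no net charge, yet the outcome at this position still changes sharply. The swap alters two things at once, the identity of the halogen and its place on the ring, and nothing measured here explains the size of the step.

The compounds shown cannot say whether the loss follows the change from chlorine to fluorine, the move of the halogen, or the two together; a 3-fluorophenyl or a 2-chlorophenyl group at this position would separate those two changes. From the compounds shown here alone, how other groups on this ring would behave also remains open, for example a methoxy group or a nitrile, and so does whether the effect of the swap would hold with another group in place of the 4-hydroxyphenyl group.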